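The source may hold more compounds than are shown below. What is called first, only, known or untested is meant among the compounds shown, and "the series" means these compounds.

Measured compounds: compound 1 `COc1ccc(OC)c(-c2cc(-c3ccc(Cl)cc3)nn2-c2ccc(S(=O)(=O)NC(C)=O)cc2)c1` gives 53200 nM; compound 2 `NS(=O)(=O)c1ccc(-n2nc(-c3ccc(Cl)cc3)cc2-c2cc(O)ccc2O)cc1` gives 35400 nM; compound 3 `CC(=O)NS(=O)(=O)c1ccc(-n2nc(-c3ccccc3)cc2-c2cc(O)ccc2O)cc1` gives 100000 nM in a functional assay on cells (Cancer cell lines, Homo sapiens) for cytotoxicity, read by sulforhodamine B assay, with a stated time of 48 h; on this read-out lower numbers stand for stronger inhibition of growth and higher numbers for weaker inhibition of growth.

Among these three numbers compound 3 stands at the highest, so the weakest inhibition of growth. Its value and that of compound 1 lie within the scatter, while compound 2 sits beyond the scatter below it. Compound 4 `CC(=O)NS(=O)(=O)c1ccc(-n2nc(-c3ccc(Cl)cc3)cc2-c2cc(O)ccc2O)cc1` is not yet measured. It differs from compound 3 by chloro in place of hydrogen on an aromatic carbon. Within the data shown here, no measured pair shows this exact change on its own. Since compound 2, which carries the chloro group, gives 35400 nM, a modest step towards stronger inhibition is expected for compound 4, though it may fall within the scatter. The expected step from compound 3 to compound 4 is a 2.0-fold lower number from compound 3 to compound 4 (0.30 log units; within the scatter), giving compound 4 an estimated 50000 nM, ranging from 20000 nM to 100000 nM.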

Compound 4, concentration for total growth inhibition: 59800 nM
The estimate for compound 4 lay 1.2-fold (0.08 log units) below the measured number; measured number inside the range.
By their numbers in this assay, from the lowest: compounds 2, 1, 4 and 3 (each within the scatter of the next, the first and the last beyond it).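

Chloro in place of hydrogen on this aromatic carbon, seen alone for the first time, gives only a small change in this assay (a 1.7-fold lower number from compound 3 to compound 4 (0.22 log units; within the scatter)). The other two single changes are equally small: acetyl in place of hydrogen on the sulfonamide nitrogen (a 1.7-fold higher number from compound 2 to compound 4 (0.23 log units; within the scatter)) and 2,5-dihydroxyphenyl in place of 2,5-dimethoxyphenyl (a 1.1-fold higher number from compound 1 to compound 4 (0.05 log units; within the scatter)). Nothing available accounts for the size of these steps.

From the compounds shown here alone, whether an amine or a carboxylic acid at this position would give a step beyond the scatter stays open.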